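The source may hold more compounds than are shown below. What is called first, only, known or untested is meant among the compounds shown, and "the series" means these compounds.

Measured so far:
Compound 1 `CNC(=O)CCCCCCCNC(=O)c1cccc(-n2c(-c3cc(C(C)C)c(O)cc3O)n[nH]c2=O)c1`: 4600 nM
Compound 2 `CC(C)c1cc(-c2n[nH]c(=O)n2-c2ccc(C(=O)NCCCCC(=O)NO)cc2)c(O)cc1O`: 4600 nM

In a functional assay on HEL cells (Homo sapiens) for inhibition (on this read-out lower numbers stand for stronger inhibition and higher numbers for weaker inhibition), compound 1 gives 4600 nM and compound 2 gives 4600 nM, so compound 1 stands level with compound 2 within the scatter. Compound 3 `CC(C)c1cc(-c2n[nH]c(=O)n2-c2cccc(C(=O)NCCCCC(=O)NO)c2)c(O)cc1O` is not yet measured. It differs from compound 1 by hydroxycarbamoyl in place of 3-(methylcarbamoyl)propyl on a saturated chain carbon, four bonds along the chain from an amide-type nitrogen. Because compound 2 gives 4600 nM with this same hydroxycarbamoyl chain, compound 3 is expected to show no step beyond the scatter from compound 1, with a 1.3-fold lower number from compound 1 to compound 3 (0.12 log units; within the scatter) as the estimated step. Compound 3 is therefore estimated at 3500 nM in this assay, in the range 1200 nM to 10000 nM.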

Compound 3, half-maximal inhibitory concentration: 4600 nM
The estimate for compound 3 lay 1.3-fold (0.12 log units) below the measured number; low and high end bracket the measured number.
By their numbers in this assay, from the lowest: compounds 1, 2 and 3 (each within the scatter of the next).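

In this assay, the change to hydroxycarbamoyl in place of 3-(methylcarbamoyl)propyl on a saturated chain carbon, four bonds along the chain from an amide-type nitrogen, gives no change at the digits printed from compound 1 to compound 3 (within the scatter) and so leaves the read-out within the scatter. At this position, the read-out therefore does not separate these two end groups, although the entering group has fewer heavy atoms. No measurement shown explains why they stand level. On these data alone, it remains open whether a carboxylic acid or an amine at this chain end would also stand level with them.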